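Chloro in Place of Hydrogen on a Quinolinol Core

A few compounds are considered here, and "the series" means these few. Any claim that something is new, unique, unknown or untested is made for them only; others in the source may bear on it.

The series is tested in a functional assay on A-431 cells (Homo sapiens) for inhibition, with a stated time of 72 h; a higher number here means a weaker inhibitor, a lower number a stronger inhibitor. Among the compounds with values here, compound 1 `Oc1c(CN2CCCC2)ccc2cccnc12` gives 16600 nM there, the highest of the two numbers measured so far; its nearest neighbour is compound 2 `Oc1c(CN2CCCCC2)ccc2cccnc12`, which gives 9770 nM. Within the data shown here, the only step between measured compounds, a 1.7-fold lower number from compound 1 to compound 2 (0.23 log units; within the scatter), concerns piperidin-1-yl in place of pyrrolidin-1-yl on a saturated chain carbon bound to an aromatic carbon, and it stays within the scatter.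

Compound 3 `Oc1c(CN2CCCC2)cc(Cl)c2cccnc12` is not yet measured. It differs from compound 1 by chloro in place of hydrogen on an aromatic carbon. Among the measured compounds shown here, no measured step touches this position, so the step from compound 1 to compound 2 carries no information about it, and no direction can be read from the data. In this assay compound 3 is therefore expected to land near compound 1, with an estimate of 12000 nM and a range from 3000 nM to 50000 nM. The expected step is a 1.4-fold lower number from compound 1 to compound 3 (0.14 log units; within the scatter), wide in both directions.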

Compound 3, half-maximal inhibitory concentration: 7410 nM
Estimate against measurement, compound 3: 1.6-fold (0.21 log units) above, within the range that was stated.
By their numbers in this assay, from the lowest: compounds 3, 2 and 1 (each within the scatter of the next, the first and the last beyond it).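

In this assay, the aromatic carbon para to a hydroxy group and ortho to a fused ring accepts chloro in place of hydrogen with no loss of inhibition, giving a 2.2-fold lower number from compound 1 to compound 3 (0.35 log units; beyond the scatter) in a modest change. Within the data shown here, this is the first step to pass beyond the scatter, whereas a 1.7-fold lower number from compound 1 to compound 2 (0.23 log units; within the scatter) at the saturated chain carbon did not. No accompanying measurement bears on why the chloro step occurs.

What the compounds shown leave open is whether this step belongs to chloro itself, since bromo, methyl and methoxy at the same position are not among them. They also leave open whether chloro gives a step of similar size when piperidin-1-yl takes the place of pyrrolidin-1-yl, as in compound 2.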